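The compounds below may be only part of what the source reports. "The series", "measured", "known", "first", "only" and "open" are said of these compounds alone.

Measured compounds:
- compound 1, `O=C(Nc1ccccc1Cl)c1ccc(/N=N\c2c[nH]c3ccccc23)cc1`: 120000 nM
- compound 2, `Cc1ccccc1NC(=O)c1ccc(/N=N\c2c[nH]c3ccccc23)cc1`: 509000 nM

Compound 2 stands at the highest of the two numbers recorded so far in a functional assay on HCT-116 cells (Homo sapiens) for inhibition, read by MTT assay, with a stated time of 72 h; on this read-out higher numbers stand for weaker inhibition and lower numbers for stronger inhibition; its nearest neighbour is compound 1, and the step between them, a 4.2-fold higher number from compound 1 to compound 2 (0.63 log units; beyond the scatter), lies beyond the usual scatter.

The next compound, compound 3, `O=C(Nc1ccccc1F)c1ccc(/N=N\c2c[nH]c3ccccc23)cc1`, is not yet measured. Its difference from compound 2 is fluoro in place of methyl on an aromatic carbon. Going by the values given here, only one measured step bears on this change: the exchange of a halogen for a methyl group between compound 1 and compound 2, a 4.2-fold higher number from compound 1 to compound 2 (0.63 log units; beyond the scatter), which raised the number modestly. Compound 3 reverses that direction by putting a halogen back in the same place, though a different one from the chloro of compound 1. On this basis compound 3 is expected to come out with a lower number than compound 2, by a step of about a 2.5-fold lower number from compound 2 to compound 3 (0.41 log units; beyond the scatter), though the data give no direct comparison of fluoro with chloro. The estimate for compound 3 in this assay is 200000 nM, with a range from 70000 nM to 600000 nM.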

Compound 3, half-maximal inhibitory concentration: 559000 nM
Beside the measured number, compound 3's estimate is 2.8-fold (0.45 log units) below it; low and high end bracket the measured number.
By their numbers in this assay, from the lowest: compound 1; then compounds 2 and 3 (each within the scatter of the next).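

In this assay, the exchange of methyl for fluoro on this aromatic carbon, ortho to a large group, gives no difference that can be read (a 1.1-fold higher number from compound 2 to compound 3 (0.04 log units; within the scatter)), so the 2-methylphenyl and 2-fluorophenyl compounds cannot be told apart on this read-out. The earlier step from chloro to methyl could have been read as a general advantage of a halogen at this place, but compound 3 carries a halogen and goes against that reading: fluoro in place of chloro gives a modest step beyond the scatter (a 4.7-fold higher number from compound 1 to compound 3 (0.67 log units; beyond the scatter)). Among these three compounds, only the chloro compound, compound 1, stands apart, with compound 2 and compound 3 together at the higher numbers, and nothing available explains why chloro differs from the other two groups here.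

The compounds shown leave open whether the lower number of compound 1 is particular to chloro or would also appear with bromo, iodo or a trifluoromethyl group at this place. They also leave open where a methoxy group, an amine or a plain hydrogen would fall, and so whether any group here moves the number further than chloro does.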